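Replacing 4-nitrophenyl with 3,4-dimethoxyphenyl on the shared core

The source may report more compounds than this note shows. Statements on the series, on what has been measured and on what is new or still open speak of the compounds shown alone.

In a functional assay on SW-620 cells (Homo sapiens) for cytotoxicity, read by sulforhodamine B assay, with a stated time of 48 h (on this read-out lower numbers stand for stronger inhibition and higher numbers for weaker inhibition), compound 2 (`C[C@H]1CC[C@@H]2[C@@H](OC(=O)[C@]23CC(c2ccc([N+](=O)[O-])cc2)=NO3)[C@]2(C)C(=O)C=C[C@@]12O`) holds the lower of the two numbers at 9000 nM against compound 1 (`C[C@H]1CC[C@@H]2[C@@H](OC(=O)[C@]23CC(c2ccc(O)cc2)=NO3)[C@]2(C)C(=O)C=C[C@@]12O`) at 89000 nM on the same core. Compound 3 (`COc1ccc(C2=NO[C@]3(C2)C(=O)O[C@@H]2[C@H]3CC[C@H](C)[C@]3(O)C=CC(=O)[C@@]23C)cc1OC`) carries 3,4-dimethoxyphenyl in place of 4-nitrophenyl on a carbon with a double bond to nitrogen. Within the data shown here, only one measured step bears on this change: nitro in place of hydroxy on an aromatic carbon gave a 9.9-fold lower number from compound 1 to compound 2 (1.00 log units; beyond the scatter) and counts as modest. Compound 3 gives up that nitro group and again has oxygen-linked groups on the aromatic ring, as compound 1 does, so part of that step is expected to be lost. The expected step is a 3.3-fold higher number from compound 2 to compound 3 (0.52 log units; beyond the scatter) in this assay and points to a higher number. For compound 3 the estimated value is 30000 nM within a range of 9000 nM to 100000 nM in these notes.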

Compound 3, half-maximal inhibitory concentration: 86000 nM
Compound 3: middle estimate off by 2.9-fold (0.46 log units), on the low side, and the stated range covers the measured number.
By their numbers in this assay, from the lowest: compound 2; then compounds 3 and 1 (each within the scatter of the next).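

In this assay, 3,4-dimethoxyphenyl in place of 4-nitrophenyl gives a 9.6-fold higher number from compound 2 to compound 3 (0.98 log units; beyond the scatter), which takes back essentially all of the advantage that compound 2 held. The same group in place of 4-hydroxyphenyl gives a 1.0-fold lower number from compound 1 to compound 3 (0.01 log units; within the scatter), so compound 1 and compound 3 cannot be told apart at this position, despite their different oxygen-linked groups. Among the three aromatic groups shown, only the 4-nitrophenyl of compound 2 separates from the others, and no measurement at hand accounts for that separation.

As far as these compounds go, it remains open whether the lower number of compound 2 is specific to the nitro group or would also appear with a nitrile, a trifluoromethyl or a carboxylic acid on the aromatic ring. From the compounds shown here alone, how an amine on that ring would behave also remains open.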